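The compounds below may be only part of what the source reports. "The series", "measured", "known", "first", "only" and "open" are said of these compounds alone.

Measured compounds:
compound 1 `O=C1NCCN1c1ccc(S(=O)(=O)Nc2ccc(C3CCCCC3)cc2)cc1` — in a functional assay on M21 cells (Homo sapiens) for antiproliferative activity, read by sulforhodamine B assay, with a stated time of 48 h (on this read-out lower numbers stand for stronger inhibition and higher numbers for weaker inhibition), compound 1 gives > 1000 nM, which is a limit of the assay and not a number.
compound 2 `CCc1cccc(NS(=O)(=O)c2ccc(N3CCNC3=O)cc2)c1` — in this assay compound 2 gives 82 nM.

Compound 2 holds the only number shown in this assay. Compound 1 sits at the limit of > 1000 nM in this assay, at which 1 of the 2 values shown sits. Among the compounds with values here, no pair of measured compounds differs in one place, so no measured step is available, and the two values show only that compound 2 has a number where compound 1 does not.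

The next compound, compound 3 `COc1cccc(NS(=O)(=O)c2ccc(N3CCNC3=O)cc2)c1`, differs from compound 2 at one point:

methoxy in place of ethyl on an aromatic carbon

The change keeps the size of the group and swaps a carbon chain for a group with one hydrogen-bond acceptor. With no measured step of this kind in this assay to lean on, the expected step is small, toward slightly weaker inhibition, and likely within the scatter of repeated measurements. The estimated step from compound 2 to compound 3 is a 1.8-fold higher number from compound 2 to compound 3 (0.26 log units; within the scatter). Compound 3 is expected to give 150 nM in this assay, with a range from 50 nM to 500 nM.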

Compound 3, half-maximal inhibitory concentration: 65 nM
Compound 3: middle estimate off by 2.3-fold (0.36 log units), on the high side, and the stated range covers the measured number.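

In this assay, within the data shown here, the first measured step is at the aromatic carbon meta to a large group: methoxy in place of ethyl gives a 1.3-fold lower number from compound 2 to compound 3 (0.10 log units; within the scatter), and the step lies within the scatter. The 3-ethylphenyl and 3-methoxyphenyl compounds are therefore not told apart by this read-out, so this position takes an oxygen-linked group with one hydrogen-bond acceptor in place of a carbon chain of the same heavy-atom count without a step beyond the scatter. Among these compounds, nothing measured so far gives a reason for this result.

The compounds shown leave open whether this position keeps such numbers with an amine, a carboxylic acid, a hydroxyl or a longer chain such as butyl or butoxy, since ethyl and methoxy match in heavy-atom count and say nothing about larger groups or charged ones. Compound 1 gives > 1000 nM, which is a limit of the assay and not a number, and it differs from the other two compounds in more than one place, so the part played by its cyclohexyl group cannot be read from this set.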